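A few compounds are considered here, and "the series" means these few. Any claim that something is new, unique, unknown or untested is made for them only; others in the source may bear on it.

Measured in an ADME assay on Huh-5-2 cells (Homo sapiens) for cytotoxicity (on this read-out higher numbers stand for lower toxicity in this test and lower numbers for higher toxicity in this test), so far:
- compound 1 `Cc1ccc(C#Cc2nc(C(N)=O)nn2COCCO)cc1` gives > 50 ug/mL as a limit
- compound 2 `NC(=O)c1nc(C#Cc2cccc(F)c2)n(COCCO)n1` gives 29 ug/mL as a number

Within the data shown here, compound 2 stands at 29 ug/mL as the only actual number. Compound 1 offers only the limit of > 50 ug/mL in this assay, at which 1 of the 2 values shown sits, and no number.

Compound 3 `NC(=O)c1nc(C#CCCCCl)n(COCCO)n1` carries 3-chloropropyl in place of 3-fluorophenyl on a triple-bonded carbon, counted as 3-chloropropyl in place of 3-fluorophenyl on a triple-bonded carbon in the change from compound 2. Among the measured compounds shown here, the one measured step at this place is an at least 1.7-fold lower number from compound 1 to compound 2 (0.23 log units; that floor lies within the scatter) and it swaps one aromatic group for another, so it gives no direct reading on a group without a ring. On that step alone, no change beyond the scatter is expected in this assay for this swap. The estimated step is a 1.0-fold higher number from compound 2 to compound 3 (0.01 log units; within the scatter) on this reasoning, and a reading at the limit is also possible. Expected for compound 3 is 30 ug/mL, with an estimated range from 12 ug/mL to 75 ug/mL.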

Compound 3, half-maximal cytotoxic concentration: > 50 ug/mL
Compound 3 was reported as a limit; the forecaster's own chance of this, stated with the estimate: 35%; at least 1.6-fold (0.22 log units) between middle value and limit.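

In this assay, among these compounds, compound 3 gives > 50 ug/mL, which is a limit and not a number, and it is the first compound here with no ring on the triple-bonded carbon. Placing 3-chloropropyl in place of 3-fluorophenyl gives an at least 1.7-fold higher number from compound 2 to compound 3 (0.23 log units; that floor lies within the scatter), so a group without a ring is accepted at this place with no sign of a lower number, though no change beyond the scatter can be claimed. The step between compound 1 and compound 3 cannot be read, and only compound 2 gives an actual number: the limit of > 50 ug/mL in this assay, at which 2 of the 3 values shown sit.

Open, from the compounds shown here alone, is how far compound 1 and compound 3 lie past the limit. Also open, going by these compounds, is whether an amine, a carboxylic acid or a longer chain on the triple-bonded carbon would give a number in this assay.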